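Dropping the Pyridin-4-yl Group: Compound 3 to Compound 4

The source may hold more compounds than are shown below. What is called first, only, known or untested is meant among the compounds shown, and "the series" means these compounds.

Three compounds share one core and were tested in a functional assay on A-375 cells (Homo sapiens) for antiproliferative activity, read by CCK-8 assay, with a stated time of 72 h, tested at 2 uM; a lower number here means a weaker effect, a higher number a stronger effect of the compound at the concentration tested:
Compound 1 `Nc1ccccc1NC(=O)c1ccc(CSC(=S)N2CCN(c3cccnc3)CC2)cc1` gives 40.5%.
Compound 2 `Nc1ccccc1NC(=O)c1ccc(CSC(=S)N2CCN(c3ccc(F)cc3)CC2)cc1` gives 20.9%.
Compound 3 `Nc1ccccc1NC(=O)c1ccc(CSC(=S)N2CCN(Cc3ccncc3)CC2)cc1` gives 33.1%.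

Compound 3 stands second highest of these three numbers. Its nearest neighbour is compound 1, and the step of a number 7.4 percentage points lower from compound 1 to compound 3 (within the scatter) lies within the scatter, so the two cannot be ordered. Its furthest is compound 2, and the step of a number 12.2 percentage points higher from compound 2 to compound 3 (beyond the scatter) lies beyond the scatter.

The unmeasured compound 4 `CN1CCN(C(=S)SCc2ccc(C(=O)Nc3ccccc3N)cc2)CC1` differs from compound 3 in one place: hydrogen in place of pyridin-4-yl on a saturated chain carbon bound to an amine nitrogen in a ring. All measured steps exchange one aromatic group for another on the amine nitrogen in the ring, namely a number 19.6 percentage points lower from compound 1 to compound 2 (beyond the scatter) and a number 12.2 percentage points higher from compound 2 to compound 3 (beyond the scatter) besides the step already named. Among the measured compounds shown here, none removes an aromatic ring altogether, so no step bears directly on this change, and the sizes seen, modest at most, give only a loose guide. The expectation is therefore a modest downward step, a number 8.1 percentage points lower from compound 3 to compound 4 (within the scatter), with wide uncertainty.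

For compound 4 the estimated value in this assay is 25%, expected to lie between 8% and 42%.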

Compound 4, a percentage reported as inhibition, at one concentration (the size of the read-out at that concentration, not a potency): 36.6%
Estimate against measurement, compound 4: 11.6 percentage points below, within the range that was stated.
By their numbers in this assay, from the lowest: compound 2; then compounds 3, 4 and 1 (each within the scatter of the next).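

Cutting (pyridin-4-yl)methyl back to methyl on the amine nitrogen in the ring gives a number 3.5 percentage points higher from compound 3 to compound 4 (within the scatter), so in this assay compound 3 and compound 4 cannot be told apart, and the aromatic ring that leaves is not needed to hold this level of effect. Methyl set against pyridin-3-yl gives a number 3.9 percentage points lower from compound 1 to compound 4 (within the scatter), so here too the two compounds cannot be ordered. Methyl set against 4-fluorophenyl gives a number 15.7 percentage points higher from compound 2 to compound 4 (beyond the scatter), which leaves compound 2 as the only one of the four that stands apart, lower than the other three.

Going by these compounds, whether a free hydrogen, an ethyl chain or a cyclohexyl ring on this nitrogen would fit with methyl or with 4-fluorophenyl stays open. Nothing shown explains why 4-fluorophenyl stands apart.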